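A few compounds are considered here, and "the series" means these few. Any claim that something is new, unique, unknown or untested is made for them only; others in the source may bear on it.

In a functional assay on MCF7 cells (Homo sapiens) for inhibition, read by CCK-8 assay, with a stated time of 48 h (on this read-out higher numbers stand for weaker inhibition of growth and lower numbers for stronger inhibition of growth), three compounds built on one shared core have been measured so far. Compound 1 `Cc1ccccc1Nc1nc(Nc2ccc(N3CCN(C)CC3)cn2)ncc1Cl` gives 5210 nM. Compound 2 `CCN1CCN(c2ccc(Nc3ncc(Cl)c(Nc4ccccc4C)n3)nc2)CC1` differs from compound 1 by methyl in place of hydrogen on a saturated chain carbon bound to an amine nitrogen in a ring. For compound 2 this assay reports no number but only a limit, > 100000 nM. The step of an at least 19-fold higher number from compound 1 to compound 2 (1.28 log units; beyond the scatter) is therefore known only as a bound because of the limit of > 100000 nM in this assay, at which 1 of the 3 values shown sits. Compound 3 `CCc1ccc(Nc2nc(Nc3ccc(N4CCN(C)CC4)cn3)ncc2Cl)cc1` carries a different group on the shared core, (4-ethylphenyl in place of 2-methylphenyl on a nitrogen on an aromatic ring), and in this assay compound 3 gives 8230 nM; the two numbers are within the scatter of each other, a 1.6-fold higher number from compound 1 to compound 3 (0.20 log units; within the scatter).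

Compound 4 `CC(C)c1ccc(Nc2nc(Nc3ccc(N4CCN(C)CC4)cn3)ncc2Cl)cc1` has not yet been measured. It differs from compound 3 by methyl in place of hydrogen on a saturated chain carbon bound to an aromatic carbon and a saturated chain carbon. Within the data shown here, this is the same kind of change as the one between compound 1 and compound 2, but not the same: there the methyl entered on a saturated chain carbon bound to an amine nitrogen in a ring, here it enters on a saturated chain carbon bound to an aromatic carbon and a saturated chain carbon. Among the compounds shown this kind of change occurs twice in all, and the measured instance produced the step of an at least 19-fold higher number from compound 1 to compound 2 (1.28 log units; beyond the scatter). Among the measured compounds shown here, the surroundings of the change differ, and there is no measured pair with the methyl at the place it takes in compound 4, so the earlier step is only a loose guide. The step expected from this change is a 1.5-fold higher number from compound 3 to compound 4 (0.16 log units; within the scatter), which is estimated to be smaller than the measured one. In this assay compound 4 is estimated at 12000 nM, within a range from 4000 nM to 40000 nM.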

Compound 4, concentration for 50% growth inhibition: 1880 nM
Estimate against measurement, compound 4: 6.4-fold (0.81 log units) above; measured number below the stated range.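

In this assay, the added methyl on the saturated chain carbon bound to an aromatic carbon and a saturated chain carbon gives a 4.4-fold lower number from compound 3 to compound 4 (0.64 log units; beyond the scatter), and the exchange of 2-methylphenyl for 4-isopropylphenyl gives a 2.8-fold lower number from compound 1 to compound 4 (0.44 log units; beyond the scatter). Set beside the earlier step, this shows that the change does not carry over from one core to the other in this series, in size or in direction: the same change on two cores in this assay, an at least 19-fold higher number (1.28 log units; beyond the scatter) from compound 1 to compound 2 and a 4.4-fold lower number (0.64 log units; beyond the scatter) from compound 3 to compound 4, at least 84-fold (1.92 log units) apart, beyond the scatter of two such steps. It does not show what the methyl would do at one and the same place on both cores, for it enters at a different place in each pair, and compound 2 gives only a limit: the limit of > 100000 nM in this assay, at which 1 of the 4 values shown sits.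

The compounds shown leave open whether a longer chain such as butyl, or a cyclopropyl group, in place of the isopropyl of compound 4 would lower the number further or raise it again. Also open, from the compounds shown here alone, is whether ethyl in place of methyl on the amine nitrogen in a ring would raise the number on the core of compound 4 as it did on the core of compound 1.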